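A few compounds are considered here, and "the series" means these few. Any claim that something is new, unique, unknown or untested is made for them only; others in the source may bear on it.

Working notes on the series, read in a functional assay on HeLa cells (Homo sapiens) for inhibition, read by CCK-8 assay, with a stated time of 48 h; a lower number here means a stronger inhibitor, a higher number a weaker inhibitor. Compound 1 `COc1ccc(-c2cc3nccc(-c4cc(OC)c(OC)c(OC)c4)n3n2)cc1` gives 373 nM and compound 2 `COc1ccc(-c2cc3nccc(-c4cc(OC)c(OC)c(OC)c4)n3n2)cc1N` gives 283 nM. These two values lie within the scatter of each other, so compound 2 cannot be separated from compound 1 on the numbers available. Compound 3 `COc1ccc(-c2cc3nccc(-c4cc(OC)c(OC)c(OC)c4)n3n2)cc1[N+](=O)[O-]` carries nitro in place of amino on an aromatic carbon, ortho to a methoxy group and meta to a large group. Within the data shown here, one measured step bears on this change: a 1.3-fold lower number from compound 1 to compound 2 (0.12 log units; within the scatter), with amino in place of hydrogen on an aromatic carbon. Among the measured compounds shown here, that step stays within the scatter, and no nitro compound has been measured yet. No step beyond the scatter is therefore expected in this assay, although the uncertainty is wide. The expected value for compound 3 is 400 nM, with an estimated range of 130 nM to 1300 nM. The estimated change is a 1.4-fold higher number from compound 2 to compound 3 (0.15 log units; within the scatter).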

Compound 3, half-maximal inhibitory concentration: > 10000 nM
Compound 3 was reported as a limit; the forecaster's own chance of this, stated with the estimate: 3%; middle value at least 25-fold (1.39 log units) from the limit.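

Compound 3 is reported in this assay only as a limit: the limit of > 10000 nM in this assay, at which 1 of the 3 values shown sits. Nitro in place of amino gives an at least 35-fold higher number from compound 2 to compound 3 (1.54 log units; beyond the scatter), and nitro in place of hydrogen gives an at least 26-fold higher number from compound 1 to compound 3 (1.42 log units; beyond the scatter). The aromatic carbon ortho to a methoxy group and meta to a large group is therefore not indifferent to what it carries: hydrogen and amino could not be separated there, while nitro stands clearly apart from both as the weaker inhibitor.

With only hydrogen, amino and nitro at this carbon, the compounds shown do not tell which feature of the nitro group goes with the loss, and how far compound 3 lies past its limit remains unknown. On these data alone, whether a nitrile, a carboxylic acid or an acetamide at the same carbon would read like amino or like nitro stays open.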